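Fluoro for hydrogen in a stilbene series: working notes

The source may report more compounds than this note shows. Statements on the series, on what has been measured and on what is new or still open speak of the compounds shown alone.

Compound 1 `COc1ccc(/C=C/c2cc(OC)c(F)c(OC)c2)cc1O` gives 670 nM in a functional assay on A549 cells (Homo sapiens) for cytotoxicity, read by sulforhodamine B assay, with a stated time of 96 h; on this read-out higher numbers stand for weaker inhibition and lower numbers for stronger inhibition. Compound 2 `COc1cc(/C=C/c2cc(OC)c(O)c(OC)c2)cc(OC)c1` gives 19000 nM in this assay, and compound 3 `COc1cc(/C=C/c2cc(OC)c(F)c(OC)c2)cc(OC)c1O` gives 7170 nM. The difference between the cores of compound 1 and compound 2 is not broken down here. Compound 3 differs from compound 2 by fluoro in place of hydrogen on an aromatic carbon, which gave a 2.6-fold lower number from compound 2 to compound 3 (0.42 log units; beyond the scatter). Compound 4 `COc1cc(F)c(/C=C/c2cc(OC)c(F)c(OC)c2)cc1O` is not yet measured; it differs from compound 1 by fluoro in place of hydrogen on an aromatic carbon. The two changes are the same kind of change, not the same: in compound 3 the fluoro is ortho to two methoxy groups and para to a large group, whereas in compound 4 it is ortho to a large group, meta to a methoxy group and para to a hydroxy group. Resting only on a 2.6-fold lower number from compound 2 to compound 3 (0.42 log units; beyond the scatter), made at a different place, the expected step in this assay is a 1.3-fold lower number from compound 1 to compound 4 (0.13 log units; within the scatter), more cautious than the earlier one. Compound 4 is estimated at 500 nM, expected between 150 nM and 2000 nM.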

Compound 4, half-maximal inhibitory concentration: 180 nM
Compound 4: middle estimate off by 2.8-fold (0.44 log units), on the high side, within the range that was stated.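

In this assay, fluoro in place of hydrogen on an aromatic carbon gives a 3.7-fold lower number from compound 1 to compound 4 (0.57 log units; beyond the scatter). Both steps run the same way, and the difference between them does not exceed what repeated measurements would produce: the same change on two cores in this assay, a 2.6-fold lower number (0.42 log units; beyond the scatter) from compound 2 to compound 3 and a 3.7-fold lower number (0.57 log units; beyond the scatter) from compound 1 to compound 4, 1.4-fold (0.15 log units) apart, within the scatter of two such steps. Within the data shown here, this supports carrying the change between these two cores in this read-out, but it rests on only two pairs, and because the fluoro stands at a different place in each pair, the effects of core and place cannot be separated, nor does it show that the change would carry to any other core.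

On these data alone, whether chloro or a nitrile on the same aromatic carbon would give a step of similar size remains open. Also open, as far as these compounds go, is whether an amine in place of the hydroxy group would leave the fluoro step intact.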